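This account rests on a few compounds, and the source may have more. Where it says the series, first, only, none or still open, it means among the compounds named here.

Three compounds share one core and differ only in the group set on one aromatic carbon. Compound 3 `COc1ccc(-c2csc(C(=O)N(C)C)n2)cc1S(=O)(=O)Nc1cccc(NCCNC(=O)c2cccc(C)c2)c1` carries a 2-(dimethylcarbamoyl)-1,3-thiazol-4-yl there; in a functional assay on CHO-RD-HGA16 cells for agonist activity at Orexin/Hypocretin receptor type 1 (Homo sapiens), read by fluorescence and calcium flux, with a stated time of 30 min (on this read-out higher numbers stand for an effect only at larger amounts of compound and lower numbers for an effect already at smaller amounts), compound 3 gives 928 nM, the second highest of the three numbers. Compound 2 `COc1ccc(-c2cccc(C(=O)N(C)C)n2)cc1S(=O)(=O)Nc1cccc(NCCNC(=O)c2cccc(C)c2)c1`, with a 6-(dimethylcarbamoyl)pyridin-2-yl, gives 226 nM in this assay, and compound 1 `COc1ccc(-c2cncc(C(=O)N(C)C)c2)cc1S(=O)(=O)Nc1cccc(NCCNC(=O)c2cccc(C)c2)c1`, with a 5-(dimethylcarbamoyl)pyridin-3-yl, gives 7530 nM. The measured steps were a 33-fold lower number from compound 1 to compound 2 (1.52 log units; beyond the scatter), an 8.1-fold lower number from compound 1 to compound 3 (0.91 log units; beyond the scatter) and a 4.1-fold higher number from compound 2 to compound 3 (0.61 log units; beyond the scatter), so the identity of this ring group moves the number over a wide span among these three.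

Compound 4 `COc1ccc(/C=C/C(=O)N(C)C)cc1S(=O)(=O)Nc1cccc(NCCNC(=O)c2cccc(C)c2)c1` goes further: 2-(dimethylcarbamoyl)ethenyl in place of 2-(dimethylcarbamoyl)-1,3-thiazol-4-yl on an aromatic carbon. The open chain keeps the dimethylcarbamoyl group but drops the five-membered aromatic ring entirely. Going by the values given here, no measured step removes a ring at this position, so the three steps set only the scale: every exchange of the ring group shifted the number modestly or largely, never within the scatter. A new kind of change is therefore expected to shift the number again, and with more uncertainty than a ring-for-ring swap. The estimate for compound 4 in this assay is a higher number, a 3.8-fold higher number from compound 3 to compound 4 (0.58 log units; beyond the scatter), giving an expected 3500 nM with a range from 800 nM to 15000 nM.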

Compound 4, half-maximal effective concentration: > 10000 nM
Compound 4: only a limit was reported; the forecaster's own chance of this, stated with the estimate: 15%; at least 2.8-fold (0.45 log units) between middle value and limit.
By their numbers in this assay, from the lowest: compound 2; then compound 3; then compound 1. At a limit, above all of these: compound 4.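

In this assay compound 4 gives > 10000 nM, which is a limit and not a number, and it is the only such value among these compounds: the limit of > 10000 nM in this assay, at which 1 of the 4 values shown sits.

Going by these compounds alone, the earlier compounds showed only that exchanging one aromatic ring for another moves the number, whereas this change replaces the ring with an open chain while keeping the dimethylcarbamoyl group. The result is an at least 10-fold higher number from compound 3 to compound 4 (1.03 log units; beyond the scatter) and an at least 44-fold higher number from compound 2 to compound 4 (1.64 log units; beyond the scatter), so at this position, para to a methoxy group, the 2-(dimethylcarbamoyl)ethenyl does not match the 2-(dimethylcarbamoyl)-1,3-thiazol-4-yl or the 6-(dimethylcarbamoyl)pyridin-2-yl. Against the 5-(dimethylcarbamoyl)pyridin-3-yl the step is an at least 1.3-fold higher number from compound 1 to compound 4 (0.12 log units; that floor lies within the scatter); that floor lies within the scatter, so the open chain cannot be ranked against that ring group.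

On these data alone, what remains open is whether the ring itself or the double bond of the chain matters more, for instance whether a saturated 2-(dimethylcarbamoyl)ethyl chain would behave like the ethenyl chain. As far as these compounds go, all four compounds also carry the same dimethylcarbamoyl group, so it is equally open how the thiazole or the pyridines would fare with a carboxylic acid or a primary amide in its place.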